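The compounds below may be only part of what the source reports. "The series", "measured", "known", "first", "only" and "open" are said of these compounds alone.

Of the compounds shown here, three built on one shared core have so far been tested in a functional assay on BE(2)-C cells (Homo sapiens) for inhibition, read by MTT assay, with a stated time of 72 h; on this read-out lower numbers stand for stronger inhibition of growth and higher numbers for weaker inhibition of growth. Compound 1 `O=S(=O)(NCCCNCc1cccc2ccccc12)c1cc(C(F)(F)F)cc(C(F)(F)F)c1` gives 2700 nM. Compound 2 `O=S(=O)(NCCCNCc1cccc(Cl)c1)c1cc(C(F)(F)F)cc(C(F)(F)F)c1` gives 6900 nM, and the step of a 2.6-fold higher number from compound 1 to compound 2 (0.41 log units; beyond the scatter) lies beyond the scatter. Compound 3 `CN(CCCNS(=O)(=O)c1cc(C(F)(F)F)cc(C(F)(F)F)c1)Cc1ccccc1` gives 28000 nM, the highest number of the three, so it inhibits growth least of these compounds; the step of a 4.1-fold higher number from compound 2 to compound 3 (0.61 log units; beyond the scatter) is also beyond the scatter.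

Compound 4 `COc1ccccc1CNCCCNS(=O)(=O)c1cc(C(F)(F)F)cc(C(F)(F)F)c1` has not yet been measured in this assay. It differs from compound 3 in one place: (2-methoxybenzyl)amino in place of benzyl(methyl)amino on a saturated chain carbon, three bonds along the chain from a sulfonamide nitrogen. Among the compounds with values here, only one measured step bears directly on this change, the one from compound 2 to compound 3, in which benzyl(methyl)amino replaced (3-chlorobenzyl)amino and the number rose modestly, as a 4.1-fold higher number from compound 2 to compound 3 (0.61 log units; beyond the scatter) shows. Compound 4 goes the other way, bringing back an amino group with a hydrogen-bond donor, so a modest fall in the number is expected, about the size of that step. For compound 4 a value of 7000 nM is expected. The estimated range for compound 4 runs from 2500 nM to 20000 nM. The step this estimate means is a 4.0-fold lower number from compound 3 to compound 4 (0.60 log units; beyond the scatter), expected to be beyond the scatter.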

Compound 4, concentration for 50% growth inhibition: 3600 nM
Compound 4: middle estimate off by 1.9-fold (0.29 log units), on the high side; the measured number falls inside the stated range.
By their numbers in this assay, from the lowest: compounds 1, 4 and 2 (each within the scatter of the next, the first and the last beyond it); then compound 3.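

In this assay, the swap at this place gives a 7.8-fold lower number from compound 3 to compound 4 (0.89 log units; beyond the scatter), which shows that a compound with benzyl(methyl)amino here can be improved on by a group that carries a hydrogen-bond donor on that same amine nitrogen. The aromatic group on the amine also proves fairly forgiving, since a 1.9-fold lower number from compound 2 to compound 4 (0.28 log units; within the scatter) and a 1.3-fold higher number from compound 1 to compound 4 (0.12 log units; within the scatter), so 2-methoxyphenyl cannot be told apart from either 3-chlorophenyl or naphthalen-1-yl, even though those two are separated by a 2.6-fold higher number from compound 1 to compound 2 (0.41 log units; beyond the scatter). No measurement is available that explains why these numbers move as they do.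

On these data alone, the step from compound 3 to compound 4 changes two things at once, removing the methyl group from the amine nitrogen and adding a methoxy group to the ring, so the share of each stays unknown, and a plain benzylamino group at this place would be needed to separate them. Also open, as far as these compounds go, is how the growth inhibition responds to the rest of the molecule, for instance a longer chain between the sulfonamide nitrogen and the amine, or an amide in place of the amine.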